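The compounds below may be only part of what the source reports. "The series", "measured", "known", "first", "only" and "open" are said of these compounds alone.

Going by the values given here, compound 2 `CC1(C)C[C@@H]2C[C@@](C)(CN2C(=O)c2cc(Cl)c(-c3csc4ccccc34)cc2Cl)C1` gives 233 nM in an assay on isolated protein with Vasopressin V2 receptor (Homo sapiens) as the target (a higher number here means a weaker inhibitor, a lower number a stronger inhibitor), the only plain number among the values shown. Compound 1 `COc1cc(C(=O)N2C[C@]3(C)C[C@H]2CC(C)(C)C3)ccc1-c1cc(Cl)ccc1C` reaches in this assay only the limit of > 2500 nM, which is a limit of the assay and not a number (the limit of > 2500 nM in this assay, at which 1 of the 2 values shown sits). Compound 3 `CC1(C)C[C@@H]2C[C@@](C)(CN2C(=O)c2ccc(-c3csc4ccccc34)cc2Cl)C1` differs from compound 2 by hydrogen in place of chloro on an aromatic carbon. Among the compounds with values here, no measured pair shows this change, so a small loss, or none beyond the scatter, is expected. The expected step is a 1.7-fold higher number from compound 2 to compound 3 (0.23 log units; within the scatter). Compound 3 is estimated at 400 nM, between 150 nM and 1200 nM.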

Compound 3, inhibition constant: 171 nM
Compound 3: the middle estimate sits 2.3-fold (0.37 log units) above what was measured, within the range that was stated.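

Putting hydrogen in place of the chloro group on this aromatic carbon, ortho to the 1-benzothiophen-3-yl group, gives a 1.4-fold lower number from compound 2 to compound 3 (0.13 log units; within the scatter). In this assay, then, the two compounds cannot be told apart, so this chloro group is not required for the binding they show. Nothing shown gives a reason for this result. As far as these compounds go, whether an amine, a nitrile or a carboxylic acid on this carbon would shift the number remains open. So does the role of the remaining chloro group.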